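The source may hold more compounds than are shown below. What is called first, only, known or untested is meant among the compounds shown, and "the series" means these compounds.

Measured so far in a functional assay on Hs-578T cells (Homo sapiens) for cytotoxicity, read by sulforhodamine B assay, with a stated time of 48 h, tested at 1 uM; on this read-out higher numbers stand for a weaker effect at the one concentration tested and lower numbers for a stronger effect:
- compound 1 `COc1ccc(-c2cc(/C=C/C(=O)c3ccc(N)cc3)[nH]n2)cc1`: 93%
- compound 2 `COc1ccc(-c2cc(/C=C/C(=O)c3ccc(N)cc3)[nH]n2)cc1OC`: 96%
- compound 3 `COc1cc(C(=O)/C=C/c2cc(-c3cc(OC)c(OC)c(OC)c3)n[nH]2)cc(OC)c1OC`: 80%

Compound 1 and compound 2 share a core and differ by hydrogen in place of methoxy on an aromatic carbon; the measured step is a number 3 percentage points lower from compound 2 to compound 1 (within the scatter). Compound 3 carries a different core; the difference between the two cores is not broken down here. Compound 3 gives the lowest of the three numbers, and its gap to compound 1 and to compound 2 lies beyond the scatter.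

Compound 4 `COc1ccc(-c2cc(/C=C/C(=O)c3cc(OC)c(OC)c(OC)c3)[nH]n2)cc1OC` is not yet measured. It differs from compound 3 by hydrogen in place of methoxy on an aromatic carbon. This is the same kind of change as from compound 2 to compound 1, but the surroundings are not identical: in compound 3 the changed carbon is also meta to a methoxy group. The expected step of a number 3 percentage points higher from compound 3 to compound 4 (within the scatter) rests on the measured step of a number 3 percentage points lower from compound 2 to compound 1 (within the scatter), which stayed within the scatter. Compound 4 is therefore expected to give 83% in this assay. The expected range for compound 4 is 70% to 96%.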

Compound 4, a percentage reported as activity, at one concentration (the size of the read-out at that concentration, not a potency): 86%
Estimate against measurement, compound 4: 3 percentage points below, within the range that was stated.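

Hydrogen in place of methoxy on an aromatic carbon, read in this assay, gives a number 6 percentage points higher from compound 3 to compound 4 (within the scatter), and the step can be set beside the earlier one on the other core: the same change on two cores in this assay, a number 3 percentage points lower (within the scatter) from compound 2 to compound 1 and a number 6 percentage points higher (within the scatter) from compound 3 to compound 4, 9 percentage points apart, within the scatter of two such steps. On these two cores, the change therefore stays within the scatter and the two steps do not differ. Among the compounds shown here, this does not show that the step would carry to a further core or to another place on the ring, and it does not show that the two steps are identical, as only one pair per core is available at one tested concentration.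

The compounds shown leave open what other replacements at this carbon would do, for example an ethoxy group or a carboxylic acid in place of the methoxy. Also open, as far as these compounds go, is whether the same change would stay within the scatter on a core where the read-out lies further from that of compound 3.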